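The source may hold more compounds than are shown below. What is called first, only, known or untested is meant among the compounds shown, and "the series" means these compounds.

Compound 1 `CC1(C)Oc2ccc(C#N)cc2[C@@H](NC(=O)Nc2ccccc2)[C@@H]1O`: 800 nM
Compound 2 `CC1(C)Oc2ccc(C#N)cc2[C@@H](NC(=O)Nc2ccccc2)[C@H]1O`: 6200 nM
Compound 3 `CC(=O)O[C@H]1[C@H](NC(=O)Nc2ccccc2)c2cc(C#N)ccc2OC1(C)C`: 4400 nM

Of the compounds shown here, three sharing one core have been measured in a functional assay (aorta) for inhibition, with Rattus norvegicus as the target; on this read-out higher numbers stand for weaker inhibition and lower numbers for stronger inhibition. Compound 1 gives 800 nM, and compound 2 gives 6200 nM; the step between them, a 7.8-fold higher number from compound 1 to compound 2 (0.89 log units; beyond the scatter), arises because of the fact that compounds 1 and 2 differ only in the configuration as drawn. Compound 3 gives 4400 nM, which places it second highest of the three numbers, close to compound 2 and well apart from compound 1; the step of a 5.5-fold higher number from compound 1 to compound 3 (0.74 log units; beyond the scatter) shows that the acetyl on the oxygen costs potency.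

Compound 4 `CC1(C)C[C@H](NC(=O)Nc2ccccc2)c2cc(C#N)ccc2O1` has not yet been measured. It differs from compound 3 by hydrogen in place of acetoxy on a saturated ring carbon. Neither measured step covers this change directly: one changes the configuration, the other adds acetyl to the oxygen. Both, however, show that altering the group on that ring carbon moves the number upward by a modest amount, and a free hydroxyl in the configuration of compound 1 appears to be the favourable arrangement. Removing the acetoxy altogether is expected to leave the number near that of compound 3, with some chance of a further rise. Compound 4 is therefore expected to give 5000 nM in this assay, within a range from 1500 nM to 15000 nM. This corresponds to an expected step of a 1.1-fold higher number from compound 3 to compound 4 (0.06 log units; within the scatter).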

Compound 4, half-maximal inhibitory concentration: 1800 nM
Beside the measured number, compound 4's estimate is 2.8-fold (0.44 log units) above it; low and high end bracket the measured number.
By their numbers in this assay, from the lowest: compound 1; then compound 4; then compounds 3 and 2 (each within the scatter of the next).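

In this assay, a substituent on this saturated ring carbon proves not to be required, since hydrogen in place of acetoxy gives a 2.4-fold lower number from compound 3 to compound 4 (0.39 log units; beyond the scatter), so the acetyl ester's loss of potency is not a loss that the bare carbon shares in full. Replacing hydroxy with hydrogen runs in opposite directions depending on the compound it starts from: one replacement gives a 3.4-fold lower number from compound 2 to compound 4 (0.54 log units; beyond the scatter), while the other gives a 2.3-fold higher number from compound 1 to compound 4 (0.35 log units; beyond the scatter). Measured against hydrogen, the hydroxy is thus favourable in one configuration and unfavourable in the other, and this reversal arises because of a single difference: the fact that compounds 1 and 2 differ only in the configuration as drawn.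

The compounds shown leave open whether a methoxy group, an amine or a fluorine on this carbon would behave like the hydroxy of compound 1 or like the acetoxy of compound 3. They also leave open whether the reversal seen with the hydroxy would hold in any read-out other than this assay.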